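The source may report more compounds than this note shows. Statements on the series, on what has been measured and on what is new or still open speak of the compounds shown alone.

In a functional assay on a cell-free system (plasma, Oryctolagus cuniculus) for inhibition, with stated times of 5 min, 1 min and 6 min (on this read-out lower numbers stand for stronger inhibition and higher numbers for weaker inhibition), compound 1 `CCOC(=O)COn1c(-c2cccc(C#N)c2)nc(C)c1C(=O)OCC` gives 6800 nM, compound 2 `CCOC(=O)c1c(C)nc(-c2cccc(C#N)c2)n1OCc1ccccc1F` gives 8990 nM and compound 3 `CCOC(=O)c1c(C)nc(-c2cccc(C#N)c2)n1OCc1ccc(Br)cc1` gives 24600 nM. Compound 3 therefore has the highest number of the three, and its gaps to both others lie beyond the scatter. Compound 4 `CCOC(=O)c1c(C)nc(-c2cccc(C#N)c2)n1OCc1ccc([N+](=O)[O-])cc1` differs from compound 3 in a single place: nitro in place of bromo on an aromatic carbon. This puts nitro in place of bromo on an aromatic carbon, para to a large group. Within the data shown here, no measured pair makes this exact exchange, so the nearest evidence comes from changes to the same side chain. The data show a 2.7-fold higher number from compound 2 to compound 3 (0.44 log units; beyond the scatter), a modest step, and a 3.6-fold higher number from compound 1 to compound 3 (0.56 log units; beyond the scatter), also modest, while a 1.3-fold higher number from compound 1 to compound 2 (0.12 log units; within the scatter) stays within the scatter. With compound 3 at 24600 nM at the top of this small range, a step somewhat toward a lower number seems more likely than a further rise, though probably not one clearly beyond the scatter. The expected change is a 1.5-fold lower number from compound 3 to compound 4 (0.19 log units; within the scatter). For compound 4 the estimated value is 16000 nM, with an expected range from 7000 nM to 36000 nM.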

Compound 4, half-maximal inhibitory concentration: 8750 nM
For compound 4 the middle estimate is 1.8-fold (0.26 log units) above the measured one; low and high end bracket the measured number.
By their numbers in this assay, from the lowest: compounds 1, 4 and 2 (each within the scatter of the next); then compound 3.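

In this assay, nitro in place of bromo on an aromatic carbon, para to a large group, gives a 2.8-fold lower number from compound 3 to compound 4 (0.45 log units; beyond the scatter) and is the only step shown that changes this group alone, so the high number of compound 3 depends on the bromo group and not on the benzyl side chain as such. The 4-nitrophenyl side chain gives a 1.0-fold lower number from compound 2 to compound 4 (0.01 log units; within the scatter) and a 1.3-fold higher number from compound 1 to compound 4 (0.11 log units; within the scatter) in the other comparisons, which leaves compound 3 alone apart from the other three compounds. The data offer no measurement that accounts for the gap between bromo and nitro.

On these data alone, whether an amine or a carboxylic acid on this same aromatic carbon would read like nitro or like bromo remains open. So does the effect of a longer chain in place of the benzyl group.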